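Notes on a resorcinol-isoxazole amide series

The source may report more compounds than this note shows. Statements on the series, on what has been measured and on what is new or still open speak of the compounds shown alone.

Measured compounds:
- compound 1, `CCNC(=O)c1noc(-c2cc(C(C)C)c(O)cc2O)c1-c1cc(CO)no1`: 5 nM
- compound 2, `CCNC(=O)c1noc(-c2cc(C(C)C)c(O)cc2O)c1-c1cc(COCC(=O)OC)no1`: "not determined" (no result reported)
- compound 3, `CCNC(=O)c1noc(-c2cc(C(C)C)c(O)cc2O)c1-c1cc(CNC(C)=O)no1`: "not determined" (no result reported)

In a functional assay on A2780 cells (Homo sapiens) for inhibition (a higher number here means a weaker inhibitor, a lower number a stronger inhibitor), compound 1 gives 5 nM. For compound 2 no number is available in this assay, where it gives "not determined" (no result reported); the same holds for compound 3, which gives "not determined" (no result reported). Compound 2 therefore stands nowhere on the numbers shown: the only anchor for the series is compound 1.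

Compound 4, `CCNC(=O)c1noc(-c2cc(C(C)C)c(O)cc2O)c1-c1cc(CN(C)C)no1`, differs from compound 2 as follows: dimethylamino in place of (methoxycarbonyl)methoxy on a saturated chain carbon bound to an aromatic carbon. The side chain on the outer ring is the only point of variation across compounds 1 to 4; the shared core and the ethylamide are untouched.

Among the measured compounds shown here, with no measured step available, the expectation for the change from compound 2 to compound 4 in this assay is a shift of no more than the usual scatter, in no preferred direction, since compound 1 shows that a small substituent here is compatible with the potency of 5 nM.

Compound 4 is expected to give about 10 nM in this assay, with a range of 2 nM to 50 nM.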

Compound 4, half-maximal inhibitory concentration: 31 nM
Beside the measured number, compound 4's estimate is 3.1-fold (0.49 log units) below it; the range from low to high includes it.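

In this assay, among the compounds shown here, dimethylamino in place of hydroxy on a saturated chain carbon bound to an aromatic carbon gives a 6.2-fold higher number from compound 1 to compound 4 (0.79 log units; beyond the scatter), the first measured step at this position. The position is therefore not indifferent to the group carried there, although compound 4 still gives 31 nM in this assay with a group counted as having no hydrogen-bond donors. No available data explain this step.

Compound 2 and compound 3 give no number, so the (methoxycarbonyl)methoxy group and the side chain of compound 3 cannot be placed against hydroxy or dimethylamino. Also open, as far as these compounds go, is whether a primary amine or a carboxylic acid on the same saturated chain carbon would give a value closer to that of compound 1 or that of compound 4.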